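Urea series: tert-butyl in place of trifluoromethyl

A few compounds are considered here, and "the series" means these few. Any claim that something is new, unique, unknown or untested is made for them only; others in the source may bear on it.

Measured compounds:
compound 1, `COc1ccc(NC(=O)OC(CCN(C)C)c2ccc(Cl)cc2)cc1`: 1660 nM
compound 2, `COc1ccc(NC(=O)NC(CCN(C)C)c2ccc(Cl)cc2)cc1`: 2000 nM
compound 3, `CN(C)CCC(NC(=O)Nc1ccc(C(F)(F)F)cc1)c1ccc(Cl)cc1`: 117 nM

Three compounds of the series have numbers in an assay on NIH3T3 cells with Urotensin-2 receptor (Homo sapiens) as the target; a lower number here means that less compound is needed, a higher number that more compound is needed for the effect. Within the data shown here, compound 1 and compound 2 share the methoxy-substituted aryl end and differ only in the carbamate against the urea linker; no step is given for that pair, and their two values sit close together. Compound 3 stands lowest of the three, with compound 1 the nearer of the other two and compound 2 the further one, both beyond the scatter.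

Among the measured compounds shown here, the one measured step that bears on the aryl substituent is a 17-fold lower number from compound 2 to compound 3 (1.23 log units; beyond the scatter), a large step. Compound 4, `CN(C)CCC(NC(=O)Nc1ccc(C(C)(C)C)cc1)c1ccc(Cl)cc1`, is the next variation at that position: tert-butyl in place of trifluoromethyl on an aromatic carbon. For the measured compounds named here, there is no measured pair in this set in which one aromatic substituent without donors or acceptors is exchanged for another of the same kind, so the only guide is that the substituent at this position can move the number strongly. Without a directional precedent, the expectation is a step no larger than the scatter, a 1.7-fold higher number from compound 3 to compound 4 (0.23 log units; within the scatter), with the downside more open than the upside. Compound 4 is therefore estimated at 200 nM, within a range of 70 nM to 700 nM.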

Compound 4, half-maximal effective concentration: 275 nM
Compound 4: the middle estimate sits 1.4-fold (0.14 log units) below what was measured, within the range that was stated.
By their numbers in this assay, from the lowest: compound 3; then compound 4; then compounds 1 and 2 (each within the scatter of the next).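

In this assay, the aryl position of the urea series now has three substituents to compare, and a 7.3-fold lower number from compound 2 to compound 4 (0.86 log units; beyond the scatter) shows that the gain over methoxy is not confined to trifluoromethyl, since an all-carbon tert-butyl group also keeps much of it. The exchange of trifluoromethyl for tert-butyl is still not neutral: a 2.4-fold higher number from compound 3 to compound 4 (0.37 log units; beyond the scatter) is a modest step beyond the scatter, although the two groups match in heavy atoms and neither has hydrogen-bond donors or acceptors, so at this position the order from the lowest number is trifluoromethyl, tert-butyl, methoxy. No independent measurement on these groups is available to account for that order.

The compounds shown leave open how a nitrile, a primary amine or a carboxylic acid would behave on the same aromatic carbon, and whether a longer alkyl chain would stay with tert-butyl or move towards methoxy. On these data alone, it also remains open whether the carbamate linker of compound 1 would follow the urea when it carries trifluoromethyl or tert-butyl in place of methoxy.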